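Pyridin-2-yl in place of the substituted phenyl of compound 3

This account rests on a few compounds, and the source may have more. Where it says the series, first, only, none or still open, it means among the compounds named here.

In a functional assay on MCF7 cells (Homo sapiens) for cytotoxicity, read by MTT assay, with a stated time of 48 h (a lower number here means a stronger inhibitor, a higher number a weaker inhibitor), compound 1 (`O=C1/C(=C\c2ccccc2)S/C(=N/c2ccccc2)N1Cc1ccncc1`) gives 26400 nM, compound 2 (`CC(C)c1ccc(/C=C2/S/C(=N/c3ccccc3)N(Cc3ccncc3)C2=O)cc1`) gives 53300 nM and compound 3 (`CCOc1cc(/C=C2/S/C(=N/c3ccccc3)N(Cc3ccncc3)C2=O)ccc1O`) gives 20100 nM. Compound 3 stands level with compound 1, with a 1.3-fold lower number from compound 1 to compound 3 (0.12 log units; within the scatter), and apart from compound 2, with a 2.7-fold lower number from compound 2 to compound 3 (0.42 log units; beyond the scatter). Compound 4 (`O=C1/C(=C\c2ccccn2)S/C(=N/c2ccccc2)N1Cc1ccncc1`) has pyridin-2-yl in place of 3-ethoxy-4-hydroxyphenyl on a double-bonded chain carbon bound to a double-bonded ring carbon. Changes on this aromatic group have stayed modest so far, and the remaining one is a 2.0-fold higher number from compound 1 to compound 2 (0.31 log units; beyond the scatter). Among the compounds with values here, no measured compound carries pyridin-2-yl at this place. The expected step is a 1.2-fold higher number from compound 3 to compound 4 (0.09 log units; within the scatter), with nothing expected beyond the scatter. Compound 4 is estimated at 25000 nM, within an expected range of 11000 nM to 55000 nM.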

Compound 4, half-maximal inhibitory concentration: 21100 nM
For compound 4 the middle estimate is 1.2-fold (0.07 log units) above the measured one; the range from low to high includes it.
By their numbers in this assay, from the lowest: compounds 3, 4 and 1 (each within the scatter of the next); then compound 2.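

In this assay, within the data shown here, pyridin-2-yl, the first group at this place with a hetero atom in its ring, stands level with 3-ethoxy-4-hydroxyphenyl, with a 1.0-fold higher number from compound 3 to compound 4 (0.02 log units; within the scatter), and with phenyl, with a 1.3-fold lower number from compound 1 to compound 4 (0.10 log units; within the scatter). Among these compounds, only 4-isopropylphenyl stands apart, with a 2.5-fold lower number from compound 2 to compound 4 (0.40 log units; beyond the scatter), so a group with no hydrogen-bond donor and fewer heavy atoms than the one in compound 3 holds the same level. No measurement bears on the reason for this.

As far as these compounds go, whether an amine or a carboxylic acid on the aromatic ring at this place would move the number beyond the scatter stays open.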